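The source may report more compounds than this note shows. Statements on the series, on what has been measured and on what is new or still open speak of the compounds shown alone.

Three analogues of the shared core have a number in an assay on HepG2 cells for inhibition of 3-hydroxy-3-methylglutaryl-coenzyme A reductase (Homo sapiens); a higher number here means a weaker inhibitor, a lower number a stronger inhibitor. Compound 1 `CC(C)c1nc(C(C)(C)C)cc(-c2ccc(F)cc2)c1/C=C/[C@@H]1C[C@@H](O)CC(=O)O1` gives 20 nM. Compound 2 `CC(C)c1nc(C2CCCCC2)cc(-c2ccc(F)cc2)c1/C=C/[C@@H]1C[C@@H](O)CC(=O)O1` gives 9.5 nM. Compound 3 `CC(C)c1nc(-c2ccc(F)cc2)c(/C=C/[C@@H]2C[C@@H](O)CC(=O)O2)c(C(C)C)n1` gives 4.8 nM, the lowest of the three numbers; its gap to compound 2 lies within the scatter, its gap to compound 1 beyond it. Compound 4 `CC(C)c1nc(C2CCCCC2)nc(-c2ccc(F)cc2)c1/C=C/[C@@H]1C[C@@H](O)CC(=O)O1` is not yet measured in this assay. Compound 4 differs from compound 3 in one place: cyclohexyl in place of isopropyl on an aromatic carbon. Among the compounds with values here, one measured step bears on this exchange: a 2.1-fold lower number from compound 1 to compound 2 (0.32 log units; beyond the scatter), where the same cyclohexyl enters on an aromatic carbon, there in place of tert-butyl rather than isopropyl, and on a core that differs from that of compound 3. Compounds 1 and 3 differ in more than one place, so nothing further is known about the exchange of tert-butyl for isopropyl on its own. On this single step, a modest drop in the number is expected for compound 4 in this assay, a 1.9-fold lower number from compound 3 to compound 4 (0.28 log units; within the scatter). Compound 4 is estimated at 2.5 nM, within 1 nM to 7 nM; a result within the scatter of compound 3 would not contradict the series.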

Compound 4, half-maximal inhibitory concentration: 26 nM
The estimate for compound 4 lay 10-fold (1.02 log units) below the measured number; measured number above the stated range.
By their numbers in this assay, from the lowest: compounds 3 and 2 (each within the scatter of the next); then compounds 1 and 4 (each within the scatter of the next).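

On the core of compound 3, at the aromatic carbon between two ring nitrogen atoms, cyclohexyl in place of isopropyl gives in this assay a 5.4-fold higher number from compound 3 to compound 4 (0.73 log units; beyond the scatter). Within the data shown here, this runs opposite to the only other cyclohexyl exchange, a 2.1-fold lower number from compound 1 to compound 2 (0.32 log units; beyond the scatter), so entry of cyclohexyl on an aromatic carbon has no single direction across these compounds, although the two steps also differ in the group that leaves and in the core. Nothing available explains this reversal.

The compounds shown do not separate the effect of the leaving group from that of the core, since tert-butyl and isopropyl are never exchanged on the same core. From the compounds shown here alone, it also remains open how this carbon between the two ring nitrogen atoms would respond to a cyclopropyl group, a phenyl group or an amine such as dimethylamino, and so whether the rise seen with cyclohexyl is specific to that six-membered ring or extends to other groups.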